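This account rests on a few compounds, and the source may have more. Where it says the series, first, only, none or still open, it means among the compounds named here.

In a functional assay for antagonist activity at Alpha-1A adrenergic receptor (Oryctolagus cuniculus) (on this read-out lower numbers stand for tighter binding and higher numbers for weaker binding), compound 1 `COc1ccccc1N1CCN(CCCOc2ccccc2C(=O)N(C)C)CC1` gives 3.98 nM, and compound 2 `CN(C)C(=O)c1cccnc1NCCCN1CCN(c2ccccc2-c2ccccc2)CC1` gives 1.26 nM, the lower of the two numbers on record, the step between them lying beyond the usual scatter. Compound 3 `CC(C)c1ccccc1N1CCN(CCCNc2ncccc2C(=O)N(C)C)CC1` differs from compound 2 in one place: isopropyl in place of phenyl on an aromatic carbon. Going by the values given here, no measured pair shows this particular change, so its effect can only be guessed. The expected step from compound 2 to compound 3 is a 2.0-fold higher number from compound 2 to compound 3 (0.30 log units; within the scatter), a slight loss that may well fall within the scatter. Compound 3 is therefore estimated at 2.5 nM, with a range from 0.8 nM to 8 nM.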

Compound 3, dissociation constant: 0.398 nM
For compound 3 the middle estimate is 6.3-fold (0.80 log units) above the measured one; measured number below the stated range.
By their numbers in this assay, from the lowest: compound 3; then compound 2; then compound 1.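

At this aromatic carbon, ortho to a large group, a six-membered aromatic ring is not needed for tight binding: in this assay, isopropyl in place of phenyl gives a 3.2-fold lower number from compound 2 to compound 3 (0.50 log units; beyond the scatter). In this one pair, the group with fewer heavy atoms and no ring goes with the lower number. Nothing available explains why the number falls.

From the compounds shown here alone, whether ethyl, tert-butyl or an amine on this carbon would lower the number further remains open. A single pair also cannot show a trend across groups of different sizes.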